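A few compounds are considered here, and "the series" means these few. Any claim that something is new, unique, unknown or untested is made for them only; others in the source may bear on it.

Three measured compounds share one core and differ only in the group on an aromatic carbon of a five-membered aromatic ring with 1 nitrogen and 1 oxygen. Compound 1 `O=[N+]([O-])c1ccc(CN2CCC(n3cc(CC(OCc4cc(-c5ccccc5)no4)c4ccc(Br)cc4)nn3)CC2)cc1` carries an unsubstituted phenyl there, and in a functional assay on MCF7 cells (Homo sapiens) for cytotoxicity, with a stated time of 48 h (a lower number here means a stronger inhibitor, a higher number a weaker inhibitor), compound 1 gives > 25000 nM, a limit of the assay and not a number (the limit of > 25000 nM in this assay, at which 1 of the 3 values shown sits). Compound 2 `O=[N+]([O-])c1ccc(CN2CCC(n3cc(CC(OCc4cc(-c5ccc(Br)cc5)no4)c4ccc(Br)cc4)nn3)CC2)cc1` carries a 4-bromophenyl, and in this assay compound 2 gives 4000 nM. Compound 3 `O=[N+]([O-])c1ccc(CN2CCC(n3cc(CC(OCc4cc(-c5cccc(Br)c5)no4)c4ccc(Br)cc4)nn3)CC2)cc1` carries a 3-bromophenyl, and in this assay compound 3 gives 6000 nM. Compound 2 thus holds the lowest of the two numbers, with compound 3 close by a 1.5-fold higher number from compound 2 to compound 3 (0.18 log units; within the scatter). The steps from the bare phenyl are an at least 6.2-fold lower number from compound 1 to compound 2 (0.79 log units; beyond the scatter) and an at least 4.1-fold lower number from compound 1 to compound 3 (0.61 log units; beyond the scatter). Compound 4 `O=[N+]([O-])c1ccc(CN2CCC(n3cc(CC(OCc4cc(-c5ccccc5F)no4)c4ccc(Br)cc4)nn3)CC2)cc1` is not yet measured and differs from compound 2 as follows: 2-fluorophenyl in place of 4-bromophenyl on an aromatic carbon. The two steps from compound 1 show that bromo in place of hydrogen on an aromatic carbon brings the gain, while the step between compound 2 and compound 3 stays within the scatter. Compound 4 loses that bromo, so it is expected to move back toward weaker inhibition, a 3.8-fold higher number from compound 2 to compound 4 (0.57 log units; beyond the scatter). Compound 4 is estimated at 15000 nM, between 5000 nM and 40000 nM.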

Compound 4, half-maximal inhibitory concentration: 8000 nM
The estimate for compound 4 lay 1.9-fold (0.27 log units) above the measured number; measured number inside the range.
By their numbers in this assay, from the lowest: compounds 2, 3 and 4 (each within the scatter of the next). At a limit, above all of these: compound 1.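

The gain over the bare phenyl does not depend on bromo, since fluoro in place of hydrogen also gives a step beyond the scatter, an at least 3.1-fold lower number from compound 1 to compound 4 (0.49 log units; beyond the scatter). In this assay, the 2-fluorophenyl cannot be separated from either bromophenyl, with a 2.0-fold higher number from compound 2 to compound 4 (0.30 log units; within the scatter) and a 1.3-fold higher number from compound 3 to compound 4 (0.12 log units; within the scatter), so these compounds show no clear preference among the three substituted phenyls, even though both the halogen and its place on the phenyl differ. The true size of the gain remains unknown, as the value for compound 1 is a limit of the assay and not a number: the limit of > 25000 nM in this assay, at which 1 of the 4 values shown sits.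

From the compounds shown here alone, it remains open whether a methoxy or an amine on the phenyl would also give a step from the bare phenyl, or whether only a halogen does. Also open, going by these compounds, is whether fluoro and bromo would differ when placed at the same spot on the phenyl.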